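Adding a bromo to the benzyl group of the methoxy chalcone

The compounds below may be only part of what the source reports. "The series", "measured", "known", "first", "only" and "open" are said of these compounds alone.

Of the compounds shown here, two with a shared core have been tested in a functional assay on HepG2 cells (Homo sapiens) for inhibition, read by MTT assay, with a stated time of 48 h, tested at 10 uM; a lower number here means less inhibition of growth, a higher number more inhibition of growth at the concentration tested. Compound 2 `COc1ccc(C(=O)/C=C/c2ccc(OCc3cn(Cc4ccccc4)nn3)cc2)cc1` gives 51% and stands highest of the two numbers. Its nearest neighbour, compound 1 `O=C(/C=C/c1ccc(OCc2cn(Cc3ccccc3Br)nn2)cc1)c1ccc(Br)cc1`, gives 34% in this assay, a gap beyond the usual scatter; these two differ in more than one place, so no single change can be tied to that gap.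

Compound 3 `COc1ccc(C(=O)/C=C/c2ccc(OCc3cn(Cc4ccccc4Br)nn3)cc2)cc1` is compound 2 with one change: bromo in place of hydrogen on an aromatic carbon of the benzyl group attached to the triazole. Among the measured compounds shown here, no measured pair shows this single change on its own, so the size of its effect is unknown. The step of a number 6 percentage points lower from compound 2 to compound 3 (within the scatter) is therefore expected to be small, within the usual scatter, with no firm direction. Compound 3 is expected to give about 45% in this assay, somewhere between 28% and 62%.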

Compound 3, percent growth inhibition at one concentration: 44%
For compound 3 the middle estimate is 1 percentage points above the measured one; the range from low to high includes it.
By their numbers in this assay, from the lowest: compounds 1, 3 and 2 (each within the scatter of the next, the first and the last beyond it).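

In this assay, the change from benzyl to 2-bromobenzyl gives a number 7 percentage points lower from compound 2 to compound 3 (within the scatter), so bromo on this aromatic carbon, ortho to a large group, has no effect that can be told from the usual variation between repeats. The second single change, methoxy in place of bromo on an aromatic carbon, gives a number 10 percentage points higher from compound 1 to compound 3 (within the scatter), so it too cannot be told from that variation. Neither change on its own therefore accounts for the wider gap seen when both places differ at once.

On these data alone, whether an amine or a carboxylic acid on this same aromatic carbon would shift growth inhibition by more remains open. No other measurement bears on why these numbers stand as they do.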